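This account rests on a few compounds, and the source may have more. Where it says the series, first, only, none or still open, it means among the compounds named here.

Measured in an ADME assay on BV-2 cells (Mus musculus) for cytotoxicity, with a stated time of 24 h, tested at 50 uM; a higher number here means a weaker effect of the compound at the concentration tested, a lower number a stronger effect:
compound 1 `COc1ccccc1S(=O)(=O)/C=C/c1ccncc1` — 78.9%
compound 2 `COc1cccc(S(=O)(=O)/C=C/c2ccncc2)c1` — 21.3%
compound 3 `COc1ccccc1S(=O)(=O)/C=C/c1cncnc1` — 97.9%

Compound 1 and compound 2 share the same atoms joined differently; the difference between the two cores is not broken down here. In this assay compound 2 gives the lowest of the three numbers, well beyond the scatter from both others. One change is seen once and is to be repeated: pyrimidin-5-yl in place of pyridin-4-yl on a double-bonded chain carbon bound to a double-bonded chain carbon. It gave a number 19 percentage points higher from compound 1 to compound 3 (beyond the scatter). Compound 4 `COc1cccc(S(=O)(=O)/C=C/c2cncnc2)c1` is not yet measured; it carries the same change on the core of compound 2: pyrimidin-5-yl in place of pyridin-4-yl on a double-bonded chain carbon bound to a double-bonded chain carbon.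

Among the measured compounds shown here, for compound 4 a step of about a number 18.7 percentage points higher from compound 2 to compound 4 (beyond the scatter) is expected, resting on the single step from compound 1 to compound 3 in this assay and on the low starting number of compound 2. The estimate for compound 4 is 40%. For the measured compounds named here, the expected range for compound 4 runs from 20% to 65%, wide because only one example of the change, a number 19 percentage points higher from compound 1 to compound 3 (beyond the scatter), exists.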

Compound 4, a percentage reported as activity, at one concentration (the size of the read-out at that concentration, not a potency): 100%
Estimate against measurement, compound 4: 60 percentage points below; measured number above the stated range.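

In this assay, pyrimidin-5-yl in place of pyridin-4-yl on a double-bonded chain carbon gives a number 78.7 percentage points higher from compound 2 to compound 4 (beyond the scatter). The direction of the change is therefore shared by both cores, but its size does not carry from one core to the other: the same change on two cores in this assay, a number 19 percentage points higher (beyond the scatter) from compound 1 to compound 3 and a number 78.7 percentage points higher (beyond the scatter) from compound 2 to compound 4, 59.7 percentage points apart, beyond the scatter of two such steps. Two cores show that a step read on one core is no safe measure of its size on another, but they do not show what sets the difference, and they give no rule for a further core.

From the compounds shown here alone, it remains open whether an amine or a carboxylic acid in place of pyrimidin-5-yl would move the number in the same direction. Going by these compounds, how the change behaves on cores beyond these two also remains open.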